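Butyl on the aryl ring, following compound 3

The source may report more compounds than this note shows. Statements on the series, on what has been measured and on what is new or still open speak of the compounds shown alone.

Compound 3 `NS(=O)(=O)NCCC1CCN(c2cc(-c3ccccc3)ncn2)CC1` gives 66500 nM in a functional assay on HT-29 cells (Homo sapiens) for antiproliferative activity, read by sulforhodamine B assay, with a stated time of 48 h (on this read-out lower numbers stand for stronger inhibition of growth and higher numbers for weaker inhibition of growth), the highest of the two numbers measured in the series. Compound 2 `CC(C)(C)c1ccc(-c2cc(N3CCC(CNS(N)(=O)=O)CC3)ncn2)cc1` gives 8900 nM in this assay, a gap beyond the scatter. Compound 1 `NS(=O)(=O)NCC1CCN(c2cc(-c3ccccc3)ncn2)CC1` reaches only > 100000 nM in this assay, which is a limit and not a number.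

Compound 4 `CCCCc1ccc(-c2cc(N3CCC(CCNS(N)(=O)=O)CC3)ncn2)cc1` carries butyl in place of hydrogen on an aromatic carbon. The step that bears most directly on this change is an at least 11-fold lower number from compound 1 to compound 2 (1.05 log units; beyond the scatter), where an alkyl group likewise enters an aromatic carbon of the same ring; because of the limit of > 100000 nM in this assay, at which 1 of the 3 values shown sits, that step is known only as a floor. The step of an at least 1.5-fold lower number from compound 1 to compound 3 (0.17 log units; that floor lies within the scatter) concerns the chain and matters less here. A lower number of comparable size is therefore expected for compound 4. The estimate for compound 4 is 6000 nM, expected to lie between 1500 nM and 25000 nM. The expected step is an 11-fold lower number from compound 3 to compound 4 (1.04 log units; beyond the scatter).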

Compound 4, concentration for 50% growth inhibition: 13300 nM
Beside the measured number, compound 4's estimate is 2.2-fold (0.35 log units) below it; measured number inside the range.
By their numbers in this assay, from the lowest: compounds 2 and 4 (each within the scatter of the next); then compound 3. At a limit, above all of these: compound 1.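

With butyl in place of hydrogen on this aromatic carbon, para to a large group, the change now has a measured size in this assay: a 5.0-fold lower number from compound 3 to compound 4 (0.70 log units; beyond the scatter). The earlier alkyl step, an at least 11-fold lower number from compound 1 to compound 2 (1.05 log units; beyond the scatter), remains a floor, the value of compound 1 being a limit and not a number: the limit of > 100000 nM in this assay, at which 1 of the 4 values shown sits. Both listed pairs show a lower number with an alkyl group at this carbon, and neither goes against it.

As far as these compounds go, how an amine, a carboxylic acid or a chain longer than butyl at this carbon would read remains open.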